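Methoxy in place of fluoro: compound 2 to compound 3

This account rests on a few compounds, and the source may have more. Where it says the series, first, only, none or still open, it means among the compounds named here.

Compound 1, `COc1ccc(NC(=S)NC(=O)c2cn(-c3ccccc3)nc2-c2ccc(OC)cc2)cc1`: 4210 nM
Compound 2, `O=C(NC(=S)Nc1ccc(Cl)cc1)c1cn(-c2ccccc2)nc1-c1ccc(F)cc1`: 5470 nM

In a functional assay on MCF7 cells (Homo sapiens) for inhibition, read by CCK-8 assay, with a stated time of 48 h (a lower number here means a stronger inhibitor, a higher number a weaker inhibitor), compound 2 gives 5470 nM, the higher of the two numbers, while compound 1 gives 4210 nM, a gap within the usual scatter. Compound 3, `COc1ccc(-c2nn(-c3ccccc3)cc2C(=O)NC(=S)Nc2ccc(Cl)cc2)cc1`, differs from compound 2 by methoxy in place of fluoro on an aromatic carbon. Among the compounds with values here, no measured pair shows this change, and the two numbers at hand lie within the scatter of each other, so nothing beyond the scatter is expected in this assay for this step. The expected step is a 1.1-fold lower number from compound 2 to compound 3 (0.06 log units; within the scatter). Compound 3 is accordingly estimated at 4800 nM, with a range from 2400 nM to 9600 nM.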

Compound 3, half-maximal inhibitory concentration: 4760 nM
For compound 3 the middle estimate is 1.0-fold (0.00 log units) above the measured one; measured number inside the range.
By their numbers in this assay, from the lowest: compounds 1, 3 and 2 (each within the scatter of the next).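

In this assay, 4-methoxyphenyl in place of 4-fluorophenyl gives a step within the scatter (a 1.1-fold lower number from compound 2 to compound 3 (0.06 log units; within the scatter)), so this position accepts either group without a measurable difference. Compound 3 also connects the two earlier compounds through a single change, chloro in place of methoxy on an aromatic carbon (a 1.1-fold higher number from compound 1 to compound 3 (0.05 log units; within the scatter)). Nothing available here accounts for the size of either step. The compounds shown leave open whether an amine or a carboxylic acid at this position would give a step beyond the scatter.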